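Chain extension on a shared core: an expected outcome

The source may hold more compounds than are shown below. What is called first, only, known or untested is meant among the compounds shown, and "the series" means these compounds.

compound 1 `CCCCNCC(=O)Nc1cccc2c1CN(C)CC2c1ccccc1` — 25 mg/kg
compound 2 `CCNCC(=O)Nc1cccc2c1CN(C)CC2c1ccc(Cl)cc1` — about 25 mg/kg

In a functional assay on the whole organism for inhibition of sodium-dependent dopamine transporter (Mus musculus) (on this read-out lower numbers stand for an effect already at smaller amounts and higher numbers for an effect only at larger amounts of compound), compound 1 gives 25 mg/kg. In this assay compound 2 gives about 25 mg/kg. Compound 2 stands level with compound 1 at the digits shown, the two values lying within the scatter of each other. Compound 3 `CCCCNCC(=O)Nc1cccc2c1CN(C)CC2c1ccc(Cl)cc1` differs from compound 2 by ethyl in place of hydrogen on a saturated chain carbon, two bonds along the chain from an amine nitrogen. Among the compounds with values here, no measured pair isolates this change; compound 1 carries the butylamino chain and compound 2 the ethylamino chain, and their values do not separate. The step of no change at the digits printed from compound 2 to compound 3 (within the scatter) is therefore expected to stay within the scatter, in no clear direction. Compound 3 is estimated at 25 mg/kg, with a range from 10 mg/kg to 60 mg/kg.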

Compound 3, dose for half-maximal effect: 22 mg/kg
Beside the measured number, compound 3's estimate is 1.1-fold (0.06 log units) above it; the measured number falls inside the stated range.
By their numbers in this assay, from the lowest: compounds 3, 1 and 2 (each within the scatter of the next).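

Within the data shown here, with the ethylamino chain exchanged for butylamino on the shared chloro-bearing core, this assay shows a 1.1-fold lower number from compound 2 to compound 3 (0.06 log units; within the scatter) and thus no separation, in the first pair to isolate this change. Among these compounds, the chloro group in place of hydrogen on an aromatic carbon, also isolated here for the first time, gives a 1.1-fold lower number from compound 1 to compound 3 (0.06 log units; within the scatter) and likewise stays within the scatter. No measurement shown here accounts for either result. Still open, on these data alone, is whether a longer chain than butyl, or a carboxylic acid on this chain, would separate from these values. Whether fluoro or methoxy in place of chloro would do so also remains unanswered.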